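Nitro for Trifluoromethyl on the Sulfonamide Aryl Ring

This account rests on a few compounds, and the source may have more. Where it says the series, first, only, none or still open, it means among the compounds named here.

Compound 1 `O=S(=O)(Nc1ccc2oc(-c3ccccc3)nc2c1)c1ccc(F)c(C(F)(F)F)c1`: in an ADME assay on HEK293 cells (Homo sapiens) for cytotoxicity, read by resazurin assay, with a stated time of 48 h (on this read-out lower numbers stand for higher toxicity in this test and higher numbers for lower toxicity in this test), compound 1 gives > 100000 nM, which is a limit of the assay and not a number.
Compound 2 `O=S(=O)(Nc1ccc2oc(-c3ccccc3)nc2c1)c1ccc(Cl)cc1`: compound 2 gives 65000 nM.
Compound 3 `O=S(=O)(Nc1ccc2oc(-c3ccccc3)nc2c1)c1ccc(Cl)c(C(F)(F)F)c1`: compound 3 gives 66000 nM.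

Compound 3 is one of two compounds with a measured number, and its value and that of compound 2 lie within the usual scatter of each other, so no order between them can be read. Compound 1 reached only the limit (the limit of > 100000 nM in this assay, at which 1 of the 3 values shown sits). Two measured steps lead to compound 3: an at least 1.5-fold lower number from compound 1 to compound 3 (0.18 log units; that floor lies within the scatter) and a 1.0-fold higher number from compound 2 to compound 3 (0.01 log units; within the scatter). Neither exceeds the scatter, so changes on this aryl ring have so far left the read-out essentially unmoved.

Compound 4 `O=[N+]([O-])c1cc(S(=O)(=O)Nc2ccc3oc(-c4ccccc4)nc3c2)ccc1Cl` differs from compound 3 in one place: nitro in place of trifluoromethyl on an aromatic carbon. Both steps that bear on this ring were flat, so the expectation for compound 4 is a step of a 1.1-fold lower number from compound 3 to compound 4 (0.04 log units; within the scatter), that is, none beyond the scatter. Compound 4 is therefore estimated at 60000 nM, with a range from 25000 nM to 150000 nM.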

Compound 4, half-maximal cytotoxic concentration: 90000 nM
Compound 4: the middle estimate sits 1.5-fold (0.18 log units) below what was measured; the range from low to high includes it.
By their numbers in this assay, from the lowest: compounds 2, 3 and 4 (each within the scatter of the next). At a limit, above all of these: compound 1.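

In this assay, the read-out does not separate nitro from trifluoromethyl on the aromatic carbon ortho to a chloro group and meta to a large group, with a 1.4-fold higher number from compound 3 to compound 4 (0.13 log units; within the scatter). Nitro also shows no step beyond the scatter against hydrogen at this carbon, with a 1.4-fold higher number from compound 2 to compound 4 (0.14 log units; within the scatter), so with the chloro group in place, hydrogen, trifluoromethyl and nitro cannot be told apart here. The flat result therefore no longer rests on trifluoromethyl alone: nitro brings nitrogen, oxygen and hydrogen-bond acceptors where trifluoromethyl carried carbon, fluorine and no such acceptors, and the read-out still registers no change beyond the scatter.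

As far as these compounds go, whether an amine or a carboxylic acid on this carbon would move the number remains open, as does what replacing the chloro group would do with nitro in place. Compound 1 gave only a limit, so how far any change on this ring could raise the number cannot be sized: the limit of > 100000 nM in this assay, at which 1 of the 4 values shown sits.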